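Adding a Second Chloro Group on Two Related Cores

The source may report more compounds than this note shows. Statements on the series, on what has been measured and on what is new or still open speak of the compounds shown alone.

Compound 1 `ClCc1ccc(Cn2cnc3c(Cl)ncnc32)cc1` and compound 2 `ClCc1ccccc1Cn1cnc2ncnc(Cl)c21` are built from the same atoms joined differently; the difference between the two cores is not broken down here. In a functional assay on SK-MEL-5 cells (Homo sapiens) for cytotoxicity, read by sulforhodamine B assay, with a stated time of 48 h (on this read-out lower numbers stand for stronger inhibition of growth and higher numbers for weaker inhibition of growth), compound 1 gives 3230 nM, while compound 2 gives 1380 nM, the lowest of the three measured numbers. Compound 3 `ClCc1ccc(Cn2cnc3c(Cl)nc(Cl)nc32)cc1` arises from compound 1 by a single change, (chloro in place of hydrogen on an aromatic carbon). In this assay compound 3 gives 6460 nM, so that a 2.0-fold higher number from compound 1 to compound 3 (0.30 log units; within the scatter).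

Compound 4 `ClCc1ccccc1Cn1cnc2nc(Cl)nc(Cl)c21` has not yet been measured. For the measured compounds named here, it arises from compound 2 by chloro in place of hydrogen on an aromatic carbon, and this is the same change as the one from compound 1 to compound 3, now made on the other core. Going by the values given here, only that one earlier example of the change is measured, and it was a small step. Because a 2.0-fold higher number from compound 1 to compound 3 (0.30 log units; within the scatter), compound 4 is expected to show a 2.0-fold higher number from compound 2 to compound 4 (0.31 log units; beyond the scatter) in this assay. Among the compounds with values here, there is no measured case showing that the second core responds differently to this change, so the single earlier step is the only guide. On that basis compound 4 is estimated at 2800 nM in this assay, with a likely range from 1400 nM to 5600 nM to allow for the ordinary spread of such measurements.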

Compound 4, concentration for 50% growth inhibition: 740 nM
Beside the measured number, compound 4's estimate is 3.8-fold (0.58 log units) above it; measured number below the stated range.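

On the core of compound 2, in this assay, placing chloro on the aromatic carbon between two ring nitrogen atoms gives a 1.9-fold lower number from compound 2 to compound 4 (0.27 log units; within the scatter), a step that by itself cannot be told apart from the ordinary spread of repeated measurements. Neither step is large on its own, but they point in opposite directions, and side by side they differ by more than that spread would explain: the same change on two cores in this assay, a 2.0-fold higher number (0.30 log units; within the scatter) from compound 1 to compound 3 and a 1.9-fold lower number (0.27 log units; within the scatter) from compound 2 to compound 4, 3.7-fold (0.57 log units) apart, beyond the scatter of two such steps. This shows that the step seen on the core of compound 1 cannot simply be carried over to the core of compound 2 as a fixed amount, but with only one pair of compounds on each core, it does not show why the two cores part ways or whether the same gap would appear in other pairs from this series.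

Among the compounds shown, only hydrogen and chloro occupy this carbon, so it remains open how an amine, a methoxy group or a longer chain placed there would behave on either core. From the compounds shown here alone, it also remains open whether the gap between the two cores would hold in cell types other than the one used here.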